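From a Branched Amine to a Ring Amine: Compound 4

The compounds below may be only part of what the source reports. "The series", "measured", "known", "first", "only" and "open" are said of these compounds alone.

Compound 1 `O=C(c1ccccc1Cl)N1N=C(c2cc3ccccc3oc2=O)CC1c1ccccc1` gives 6370 nM in a functional assay on PC-3 cells (Homo sapiens) for cytotoxicity, read by MTT assay, with a stated time of 48 h; a higher number here means a weaker inhibitor, a lower number a stronger inhibitor.
Compound 2 `CCNCC(=O)N1N=C(c2cc3ccccc3oc2=O)CC1c1ccccc1` gives 5580 nM in this assay.
Compound 3 `CC(C)(C)NCC(=O)N1N=C(c2cc3ccccc3oc2=O)CC1c1ccccc1` gives 16400 nM in this assay.

Among the three measured compounds, compound 3 has the highest number and is the weakest: its steps to both others are beyond the scatter, with a 2.6-fold higher number from compound 1 to compound 3 (0.41 log units; beyond the scatter) and a 2.9-fold higher number from compound 2 to compound 3 (0.47 log units; beyond the scatter), while a 1.1-fold lower number from compound 1 to compound 2 (0.06 log units; within the scatter) is within the scatter. Compound 4 `CCN(CC)C1CCN(CC(=O)N2N=C(c3cc4ccccc4oc3=O)CC2c2ccccc2)CC1` differs from compound 3 in one place: 4-(diethylamino)piperidin-1-yl in place of (tert-butyl)amino on a saturated chain carbon bound to a carbonyl carbon.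

Within the data shown here, two steps bear on this change. The step of a 2.9-fold higher number from compound 2 to compound 3 (0.47 log units; beyond the scatter) shows that enlarging the group on the amine nitrogen from ethyl to tert-butyl raised the number modestly, and the step of a 2.6-fold higher number from compound 1 to compound 3 (0.41 log units; beyond the scatter) shows the same direction against compound 1. Among the measured compounds shown here, the new group in compound 4 is larger still, but it also removes the hydrogen-bond donor and adds a second amine nitrogen, and no measured compound carries anything like it, so the direction is uncertain. The expectation is therefore a step of a 1.8-fold lower number from compound 3 to compound 4 (0.26 log units; within the scatter) that stays near or within the scatter. For compound 4 the estimate is 9000 nM, with a range from 3000 nM to 27000 nM.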

Compound 4, half-maximal inhibitory concentration: 26100 nM
Compound 4: the middle estimate sits 2.9-fold (0.46 log units) below what was measured, and the stated range covers the measured number.
By their numbers in this assay, from the lowest: compounds 2 and 1 (each within the scatter of the next); then compounds 3 and 4 (each within the scatter of the next).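

In this assay, putting 4-(diethylamino)piperidin-1-yl in place of (tert-butyl)amino on a saturated chain carbon bound to a carbonyl carbon gives a 1.6-fold higher number from compound 3 to compound 4 (0.20 log units; within the scatter), so this position accepts a ring amine with no hydrogen-bond donor and no reading separates it from the branched amine. The larger steps lie elsewhere: a 4.7-fold higher number from compound 2 to compound 4 (0.67 log units; beyond the scatter) against ethylamino, and a 4.1-fold higher number from compound 1 to compound 4 (0.61 log units; beyond the scatter) against 2-chlorophenyl on a carbonyl carbon, which place compound 4 with compound 3, apart from compounds 1 and 2. No measurement at hand accounts for these steps.

The compounds shown leave open whether the piperidine ring or its diethylamino group decides the reading. A plain piperidin-1-yl or a morpholin-4-yl at this position would separate the two.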